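Swapping a Methyl for Trifluoromethyl on an Aromatic Ether

The source may hold more compounds than are shown below. What is called first, only, known or untested is meant among the compounds shown, and "the series" means these compounds.

Of the compounds shown here, three have been tested in a functional assay on HT-29 cells (Homo sapiens) for cytotoxicity, read by MTT assay, with a stated time of 72 h; on this read-out higher numbers stand for weaker inhibition and lower numbers for stronger inhibition. Compound 1 `COc1ccc(C(=O)c2cc(OC)c(OC)c(OC)c2)cc1N` gives 50 nM in this assay. Compound 2 `COc1cccc(/C=C/C(=O)Nc2cc(OC)c(OC)c(OC)c2)c1` gives 2400 nM, and compound 3 `COc1cccc(/C=C/C(=O)Nc2cc(C(=O)c3cc(OC)c(OC)c(OC)c3)ccc2OC)c1` gives 1900 nM. Compound 3 and compound 2 sit close together, their numbers lying within the usual scatter of repeated measurements, so no order between them can be read off. Against compound 1, however, compound 3 stands well apart: its number is far higher, a gap that lies beyond the scatter.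

Compound 4 `COc1ccc(C(=O)c2cc(OC)c(OC)c(OC)c2)cc1NC(=O)/C=C/c1cccc(OC(F)(F)F)c1` has not yet been measured. It differs from compound 3 in one place: trifluoromethyl in place of methyl on an oxygen on an aromatic ring. No pair of measured compounds shows this exact swap, so there is no precedent among these three to set the size or direction of its effect. In the absence of such a precedent, the expected step is none beyond the scatter, in either direction.

The estimate for compound 4 in this assay is therefore 1700 nM, with a plausible range from 500 nM to 6000 nM. This corresponds to an expected step of a 1.1-fold lower number from compound 3 to compound 4 (0.05 log units; within the scatter), essentially flat.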

Compound 4, half-maximal inhibitory concentration: 5200 nM
Estimate against measurement, compound 4: 3.1-fold (0.49 log units) below, and the stated range covers the measured number.
By their numbers in this assay, from the lowest: compound 1; then compounds 3 and 2 (each within the scatter of the next); then compound 4.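

In this assay the group on this oxygen proves not to be a neutral spot: the change from 3-methoxyphenyl to 3-(trifluoromethoxy)phenyl gives a 2.7-fold higher number from compound 3 to compound 4 (0.44 log units; beyond the scatter) and so weakens inhibition. This pair is the only one-place comparison among the compounds shown, which makes it the only direct reading of what a change at this position does, and it is a reading of a single swap in a single cell assay. Nothing measured here bears on why trifluoromethyl in place of methyl on this oxygen has this effect.

What the compounds shown leave open is how other groups on this oxygen would behave, for example a longer chain such as ethyl, or a hydrogen in place of the methyl, which would give a free hydroxyl. From the compounds shown here alone, it is also open whether the same swap would move the number in the same direction at the other methoxy groups of these molecules, since one pair cannot show whether this step holds beyond this place.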